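The compounds below may be only part of what the source reports. "The series", "measured", "known", "first", "only" and "open" are said of these compounds alone.

Three compounds share one core and were compared in an assay on HEK293 cells for displacement of a labelled ligand from 5-hydroxytryptamine receptor 7 (Rattus norvegicus), read by radioligand binding; a higher number here means a weaker inhibitor, a lower number a stronger inhibitor. Compound 1 `CCn1nc2c(c1-c1ccccc1)CCNCC2` gives 140 nM. Compound 2 `CC(C)n1nc2c(c1-c1ccccc1)CCNCC2` gives 28 nM, the lowest of the three numbers. Compound 3 `c1ccc(-c2c3c(nn2C2CCC2)CCNCC3)cc1` gives 90 nM. The steps among them concern only the group on the aromatic nitrogen: a 5.0-fold lower number from compound 1 to compound 2 (0.70 log units; beyond the scatter), a 3.2-fold higher number from compound 2 to compound 3 (0.51 log units; beyond the scatter), and a 1.6-fold lower number from compound 1 to compound 3 (0.19 log units; within the scatter).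

Compound 4 `CC(C)n1nc2c(c1-c1ccc(Cl)cc1)CCNCC2` differs from compound 2 at a different place: chloro in place of hydrogen on an aromatic carbon. For the measured compounds named here, none of the measured steps touches the six-membered carbon ring, so no step bears directly on this change; the measured steps only show that the core tolerates modest shifts without leaving the range seen here. With nothing to point in either direction, the expectation for this assay is a step from compound 2 to compound 4 that stays within the scatter, a 1.1-fold lower number from compound 2 to compound 4 (0.05 log units; within the scatter). Compound 4 is therefore estimated at 25 nM, with a range from 8 nM to 80 nM.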

Compound 4, inhibition constant: 9 nM
The estimate for compound 4 lay 2.8-fold (0.44 log units) above the measured number; the measured number falls inside the stated range.
By their numbers in this assay, from the lowest: compound 4; then compound 2; then compounds 3 and 1 (each within the scatter of the next).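

Until now, every step changed only the group on the aromatic nitrogen. Compound 4 shows that in this assay the six-membered aromatic ring of carbon only also responds to substitution: with isopropyl kept on the nitrogen, chloro in place of hydrogen, para to a large group, gives a 3.1-fold lower number from compound 2 to compound 4 (0.49 log units; beyond the scatter) and this lies beyond the scatter. Nothing shown here gives a measured reason for this step.

Going by these compounds, it remains open whether fluoro, methyl or methoxy at this same place would give a similar step, and whether chloro at another place on that ring would do so. On these data alone, it is also open whether chloro would give a step of similar size with ethyl or cyclobutyl on the aromatic nitrogen.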